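Lactam replacement on the fused aryl ring of compound 1

The compounds below may be only part of what the source reports. "The series", "measured", "known", "first", "only" and "open" are said of these compounds alone.

Working notes on the series. Compound 1 `CC(C)c1noc(N2CCC(Oc3cc(N4CCc5cc(N6CCCNS6(=O)=O)ccc54)ncn3)CC2)n1`, in an assay on CHO cells for agonist activity at Glucose-dependent insulinotropic receptor (Homo sapiens), read by a luciferase reporter and cAMP accumulation, with a stated time of 2 h (on this read-out lower numbers stand for an effect already at smaller amounts and higher numbers for an effect only at larger amounts of compound), gives 24 nM. Compound 2 `CC(C)c1noc(N2CCC(Oc3cc(N4CCc5cc(N6CCCC6=O)ccc54)ncn3)CC2)n1` gives 33 nM, and a 1.4-fold higher number from compound 1 to compound 2 (0.14 log units; within the scatter) stays within the scatter. Compound 3 `CC(C)SC(=O)N1CCC(Oc2cc(N3CCc4cc([S+]([O-])CCO)ccc43)ncn2)CC1` has no single number: its entries read 14 nM; 57 nM; 9.7 nM (3 entries), and the several entries of compound 3 in this assay, 14 nM; 57 nM; 9.7 nM (3 entries) shows how far repeats of one compound can spread. Compound 4 `CC(C)c1noc(N2CCC(Oc3cc(N4CCc5cc(N6CCC(O)CC6=O)ccc54)ncn3)CC2)n1` differs from compound 1 by a group of 8 heavy atoms (5 carbon, 1 nitrogen, 2 oxygen; one six-membered non-aromatic ring with 1 hetero atom) in place of a group of 8 heavy atoms (3 carbon, 2 nitrogen, 2 oxygen, 1 sulfur; one six-membered non-aromatic ring with 3 hetero atoms), on an aromatic carbon. Among the measured compounds shown here, the only measured step that bears on this is the one from compound 1 to compound 2, where another six-membered-to-lactam type exchange at the same aromatic carbon moved the number within the scatter; the expected step for compound 4 is therefore a 1.5-fold higher number from compound 1 to compound 4 (0.16 log units; within the scatter). Compound 4 is estimated at 35 nM, in a range from 14 nM to 90 nM.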

Compound 4, half-maximal effective concentration: 89 nM
The estimate for compound 4 lay 2.5-fold (0.41 log units) below the measured number; the measured number falls inside the stated range.
By their numbers in this assay, from the lowest: compounds 1 and 2 (each within the scatter of the next); then compound 4.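

Among the compounds shown here, at this aromatic carbon, meta to a fused ring and para to a fused ring, 4-hydroxy-2-oxopiperidin-1-yl gives the first step beyond the scatter in this assay: a 3.7-fold higher number from compound 1 to compound 4 (0.57 log units; beyond the scatter). Against 2-oxopyrrolidin-1-yl it gives a 2.7-fold higher number from compound 2 to compound 4 (0.43 log units; beyond the scatter), so this position does not treat these two lactams alike. Both steps are modest, and repeats of one compound can spread widely: the several entries of compound 3 in this assay, 14 nM; 57 nM; 9.7 nM (3 entries).

Still open, on these data alone, is whether the six-membered ring or the hydroxyl accounts for the step; 2-oxopiperidin-1-yl without the hydroxyl would separate them. As far as these compounds go, an amine in place of that hydroxyl is also open.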